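This account rests on a few compounds, and the source may have more. Where it says the series, first, only, none or still open, it means among the compounds named here.

Compound 1 `COc1cc2c(/C=C3/C(=O)Nc4ccc(O)cc43)c(Cl)n(Cc3cc(OC)c(OC)c(OC)c3)c2cc1C` was tested in a functional assay on cells (Leukemia cell, Homo sapiens) for cytotoxicity, with a stated time of 48 h (on this read-out higher numbers stand for weaker inhibition of growth and lower numbers for stronger inhibition of growth), where compound 1 gives 18600 nM. Among the three numbers measured so far, this is the second highest. Compound 3 `O=C1/C(=C/c2c(Cl)[nH]c3ccccc23)c2ccccc2N1Cc1ccccc1` gives 21400 nM in this assay; its value and that of compound 1 lie within the usual scatter of each other, so nothing separates them. Compound 2 `COc1cc2c(/C=C3/C(=O)Nc4ccc(Cl)cc43)c(Cl)n(Cc3cc(OC)c(OC)c(OC)c3)c2cc1C` gives 4790 nM in this assay; the change that leads to it, chloro in place of hydroxy on an aromatic carbon, brings a 3.9-fold lower number from compound 1 to compound 2 (0.59 log units; beyond the scatter), a step that is beyond the scatter.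

Compound 4 `COc1cc2c(/C=C3/C(=O)Nc4cccc(Cl)c43)c(Cl)n(Cc3cc(OC)c(OC)c(OC)c3)c2cc1C` has not yet been measured in this assay. It differs from compound 1 by a group of 12 heavy atoms (9 carbon, 1 nitrogen, 1 oxygen, 1 chlorine; one five-membered non-aromatic ring with 1 hetero atom, one six-membered aromatic ring of carbon only) in place of a group of 12 heavy atoms (9 carbon, 1 nitrogen, 2 oxygen; one five-membered non-aromatic ring with 1 hetero atom, one six-membered aromatic ring of carbon only), on an aromatic carbon. Within the data shown here, as in compound 2, a chlorine stands where compound 1 has a hydroxy group, but in compound 4 the chlorine sits on a different ring carbon, so the step from compound 1 to compound 2 is the only guide and it fits only in part. On the strength of that step, a lower number is expected for compound 4, of a size that is less certain. For compound 4 the expected step is a 2.9-fold lower number from compound 1 to compound 4 (0.46 log units; beyond the scatter). Compound 4 is therefore estimated at 6500 nM, with a range from 2500 nM to 17000 nM.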

Compound 4, concentration for total growth inhibition: 14100 nM
Beside the measured number, compound 4's estimate is 2.2-fold (0.34 log units) below it; measured number inside the range.
By their numbers in this assay, from the lowest: compound 2; then compounds 4, 1 and 3 (each within the scatter of the next).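

In this assay, a chlorine on a different ring carbon from the one that carries the hydroxy group of compound 1 gives a 1.3-fold lower number from compound 1 to compound 4 (0.12 log units; within the scatter) and so leaves nothing to separate these two compounds; a chlorine on the core is therefore not enough on its own to bring the lower number seen for compound 2. Among these compounds, the placement of the chlorine matters here, something the earlier compounds could not show with only one chlorine-bearing carbon in this ring: two groups with the same atom counts, differing in where the chlorine sits, give a 2.9-fold higher number from compound 2 to compound 4 (0.47 log units; beyond the scatter) in this series. No measurement here accounts for this difference.

Going by these compounds, it remains open how a fluoro, a methoxy or an amine would compare with chlorine on these two ring carbons, and so whether the chlorine itself or only its ring carbon sets the value. On these data alone, it is also open whether a hydroxy group on the ring carbon that holds the chlorine in compound 4 would give a number different from that of compound 4.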